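Chloro on the Aromatic Ring of Compound 1

The source may hold more compounds than are shown below. What is called first, only, known or untested is meant among the compounds shown, and "the series" means these compounds.

Compound 1 `CC(C)(C)OC(=O)/C=C1/C(=O)Nc2ccccc21` stands lowest of the two numbers in a functional assay on HL-60 cells (Homo sapiens) for cytotoxicity, read by CCK-8 assay, with a stated time of 72 h (on this read-out higher numbers stand for weaker inhibition and lower numbers for stronger inhibition), where compound 1 gives 2450 nM. Among the compounds with values here, its only neighbour, compound 2 `CC(C)(C)OC(=O)/C=C1/C(=O)N(Cc2ccccc2)c2ccccc21`, gives 13800 nM, a step of a 5.6-fold higher number from compound 1 to compound 2 (0.75 log units; beyond the scatter) that comes from a change at the ring nitrogen, not on the aromatic ring. Compound 3 `CC(C)(C)OC(=O)/C=C1/C(=O)Nc2ccc(Cl)cc21` differs from compound 1 by chloro in place of hydrogen on an aromatic carbon. Within the data shown here, no measured step touches this aromatic position, so nothing points in either direction; a step of a 1.1-fold lower number from compound 1 to compound 3 (0.05 log units; within the scatter) is expected, staying within the usual scatter. Compound 3 is therefore estimated at 2200 nM, between 700 nM and 7000 nM.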

Compound 3, half-maximal inhibitory concentration: 3160 nM
For compound 3 the middle estimate is 1.4-fold (0.16 log units) below the measured one; the measured number falls inside the stated range.
By their numbers in this assay, from the lowest: compounds 1 and 3 (each within the scatter of the next); then compound 2.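

Putting chloro in place of hydrogen on this aromatic carbon leaves compound 3 level with compound 1 in this assay (a 1.3-fold higher number from compound 1 to compound 3 (0.11 log units; within the scatter)). So this position accepts a chlorine atom without a difference that can be told from scatter, unlike the ring nitrogen, where benzyl gave a step beyond the scatter (a 5.6-fold higher number from compound 1 to compound 2 (0.75 log units; beyond the scatter)). Nothing measured here offers an explanation for this result.

Still open, as far as these compounds go, is whether a larger or differently natured group on this carbon, such as an amine or a carboxylic acid, would also leave the number level. Whether chloro on the other aromatic carbons of the core would behave in the same way is open too.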